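A Pyridine Swap Carried Onto a Weaker Core

The compounds below may be only part of what the source reports. "The series", "measured", "known", "first", "only" and "open" are said of these compounds alone.

Compound 1 `COc1ccc(/C=C/C(=O)c2ccccc2-c2ccc(F)cc2)cc1` carries a 4-fluorophenyl group and in a functional assay on HepG2 cells (Homo sapiens) for antiproliferative activity, read by sulforhodamine B assay, with a stated time of 48 h (a lower number here means a stronger inhibitor, a higher number a weaker inhibitor), gives 93 nM. Compound 2 `COc1ccc(/C=C/C(=O)c2ccccc2-c2ccc(F)nc2)cc1` differs from it by 6-fluoropyridin-3-yl in place of 4-fluorophenyl on an aromatic carbon, and in this assay compound 2 gives 290 nM, so this change produced a 3.1-fold higher number from compound 1 to compound 2 (0.49 log units; beyond the scatter). Compound 3 `O=C(/C=C/c1ccccc1-c1ccc(F)cc1)c1cccc(O)c1` is built on a different core; the difference between the two cores is not broken down here. In this assay compound 3 gives 4200 nM, the highest number of the three measured compounds, and its steps to compound 2 and to compound 1 are both beyond the scatter. Compound 4 `O=C(/C=C/c1ccccc1-c1ccc(F)nc1)c1cccc(O)c1` has not yet been measured. It differs from compound 3 by 6-fluoropyridin-3-yl in place of 4-fluorophenyl on an aromatic carbon, at a place described in the same words as for compound 2, so this is the same change seen once already. Going by the values given here, the expected step is a 2.9-fold higher number from compound 3 to compound 4 (0.46 log units; beyond the scatter), resting on the earlier step of a 3.1-fold higher number from compound 1 to compound 2 (0.49 log units; beyond the scatter); the changed core and the single prior pair leave the expectation uncertain. Compound 4 is estimated at 12000 nM, with a range from 4000 nM to 40000 nM.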

Compound 4, half-maximal inhibitory concentration: 6400 nM
Estimate against measurement, compound 4: 1.9-fold (0.27 log units) above, and the stated range covers the measured number.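

On the core of compound 3, putting 6-fluoropyridin-3-yl in place of 4-fluorophenyl in this assay gives a 1.5-fold higher number from compound 3 to compound 4 (0.18 log units; within the scatter), so on this core alone the change cannot be told apart from the scatter of repeated measurements. Set beside the step on the core of compound 1, a 3.1-fold higher number from compound 1 to compound 2 (0.49 log units; beyond the scatter), the two steps cannot be separated from each other: the same change on two cores in this assay, a 3.1-fold higher number (0.49 log units; beyond the scatter) from compound 1 to compound 2 and a 1.5-fold higher number (0.18 log units; within the scatter) from compound 3 to compound 4, 2.0-fold (0.31 log units) apart, within the scatter of two such steps The change is therefore compatible with carrying across the two cores at a similar size, but two pairs do not establish this, and they do not show whether the change has a real effect on the core of compound 3 or why the first step lies beyond the scatter.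

The compounds shown leave open how this ring would behave with an amine or a carboxylic acid in place of its fluorine on either core. They also leave open which of the several differences between the core of compound 1 and the core of compound 3 matters in this assay.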